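The source may report more compounds than this note shows. Statements on the series, on what has been measured and on what is new or still open speak of the compounds shown alone.

Measured so far in a functional assay on SUP-B15 cells (Homo sapiens) for antiproliferative activity, with a stated time of 72 h; a higher number here means that more compound is needed for the effect, a lower number that less compound is needed:
Compound 1, `COc1ccc(-c2cc(=O)c3c(OC)cc(OC)cc3n2Cc2ccccc2)cc1`: for compound 1 only a limit of this assay is recorded, > 34400 nM.
Compound 2, `COc1ccc(-c2cc(=O)c3c(OC)cc(OC)cc3n2S(=O)(=O)c2ccc(C#N)cc2)cc1`: compound 2 gives 7900 nM.
Compound 3, `COc1ccc(-c2cc(=O)c3c(OC)cc(OC)cc3n2S(=O)(=O)c2ccc(F)cc2)cc1`: for compound 3 only a limit of this assay is recorded, > 65500 nM.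

Compound 1 therefore stands at a limit, not at a number, and one of the other values shown is likewise a limit. Compound 4, `COc1ccc(-c2cc(=O)c3c(OC)cc(OC)cc3n2S(=O)(=O)c2ccc(OC)cc2)cc1`, is not yet measured; it differs from compound 1 by (4-methoxyphenyl)sulfonyl in place of benzyl on an aromatic nitrogen.

Two measured steps start from compound 1 and likewise replace the benzyl by an arylsulfonyl group. an at least 4.3-fold lower number from compound 1 to compound 2 (0.63 log units; beyond the scatter). a step that the two limits leave unreadable from compound 1 to compound 3. Between the two sulfonyl compounds, an at least 8.2-fold higher number from compound 2 to compound 3 (0.91 log units; beyond the scatter). Among the measured compounds shown here, the sulfonyl exchange alone thus does not fix the outcome; the group carried by the sulfonyl aryl ring matters, and a methoxy there has no measured counterpart. The expected direction is toward a lower number, of uncertain size, with a real chance that this assay again returns only a limit. The step expected is an at least 1.3-fold lower number from compound 1 to compound 4 (0.13 log units; that floor lies within the scatter). Compound 4 is estimated at 25000 nM, with a range from 6000 nM to 100000 nM.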

Compound 4, half-maximal effective concentration: > 82700 nM
Compound 4: only a limit was reported (the forecaster's own chance of this, stated with the estimate: 50%); middle value at least 3.3-fold (0.51 log units) away from the limit.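

In this assay compound 4 gives only a limit, > 82700 nM. Methoxy in place of cyano on the sulfonyl aryl ring gives an at least 10-fold higher number from compound 2 to compound 4 (1.01 log units; beyond the scatter), so methoxy, like fluoro, replaces the cyano without leaving a measured number, and among the arylsulfonyl compounds shown only the cyano compound has one. The steps joining compound 4 to compound 1 and to compound 3 cannot be read, with limits at both ends, and the fluoro and methoxy compounds stay unordered.

Open, as far as these compounds go, is whether the measured number depends on the nitrile itself: an amine or a carboxylic acid in place of the cyano would test this. Also open, from the compounds shown here alone, is what the sulfonyl link contributes, which a 4-cyanobenzyl group on the aromatic nitrogen would address.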